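Compound 3: a step without a measured start

The source may hold more compounds than are shown below. What is called first, only, known or untested is meant among the compounds shown, and "the series" means these compounds.

Measured in a functional assay on CWR22R cells (Homo sapiens) for antiproliferative activity, read by CCK-8 assay, with a stated time of 6 days; a higher number here means a weaker inhibitor, a lower number a stronger inhibitor:
- compound 1 `CCN(c1ccc(C#N)c(Cl)c1)c1cc(-c2ccc(F)nc2)ccc1C`: 16500 nM
- compound 2 `CCN(c1ccc(C#N)c(Cl)c1)c1cc(C2=CCCCC2)ccc1C`: "not determined" (no result reported)

Compound 2 has no place on the numbers, since no result was reported for it in this assay. The only figure available for this series is that of compound 1, at 16500 nM.

Compound 3 `CCN(c1ccc(C#N)c(Cl)c1)c1cc(-n2cccn2)ccc1C` follows from compound 2 by a single change on an aromatic carbon, para to a methyl group: 1H-pyrazol-1-yl in place of cyclohex-1-en-1-yl (1H-pyrazol-1-yl in place of cyclohex-1-en-1-yl on an aromatic carbon). A six-membered non-aromatic ring of carbon only thus gives way to a five-membered aromatic ring with 2 hetero atoms.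

With no number for compound 2, neither the size nor the direction of this step can be read from the data. For the measured compounds named here, the only guide is compound 1 at 16500 nM, so no difference from that figure beyond the usual scatter is expected, although this rests on a single measurement. For compound 3 the estimated half-maximal inhibitory concentration is 14000 nM, with an expected range of 4500 nM to 40000 nM.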

Compound 3, half-maximal inhibitory concentration: > 30000 nM
Compound 3: only a limit was reported; the forecaster's own chance of this, stated with the estimate: 15%; middle value at least 2.1-fold (0.33 log units) from the limit.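

In this assay compound 3 gives > 30000 nM, which is a limit of the assay and not a number. For the compounds shown here, exchanging 6-fluoropyridin-3-yl for 1H-pyrazol-1-yl on the aromatic carbon para to a methyl group gives the first step that can be read at this position, an at least 1.8-fold higher number from compound 1 to compound 3 (0.25 log units; that floor lies within the scatter), so the floor of the step alone does not separate the two compounds, and the true difference may be larger. Nothing in this reading places compound 3 as a stronger inhibitor than compound 1, and the comparison rests on a single bound: the limit of > 30000 nM in this assay, at which 1 of the 3 values shown sits.

The step from compound 2 to compound 3 cannot be read, so cyclohex-1-en-1-yl, the one non-aromatic ring here, remains unplaced against either aromatic ring. Also open, on these data alone, are how far compound 3 lies past its limit and whether an amine or a carboxylic acid on this same carbon would give a figure clearly apart from that of compound 1.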